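Methyl in place of hydrogen on compound 2

A few compounds are considered here, and "the series" means these few. Any claim that something is new, unique, unknown or untested is made for them only; others in the source may bear on it.

For the measured compounds named here, compound 2 (`CC(C)(C)NCc1c(C(=O)O)nn(-c2ccc(Cl)cc2)c1-c1ccccc1`) gives 175000 nM in an ADME assay on HaCaT cells (Homo sapiens) for inhibition, read by sulforhodamine B assay, with a stated time of 48 h (a higher number here means a weaker inhibitor of growth, a lower number a stronger inhibitor of growth), and this is the only actual number the series has so far. Compound 1 (`Cc1ccc(-c2c(CNC(C)(C)C)c(C(=O)O)nn2-c2ccccc2)cc1`) reads > 688000 nM in this assay, which is a limit of the assay and not a number.

Compound 3 (`Cc1ccc(-c2c(CNC(C)(C)C)c(C(=O)O)nn2-c2ccc(Cl)cc2)cc1`) keeps the rest of compound 2 and takes methyl in place of hydrogen on an aromatic carbon, para to a large group, so that phenyl becomes 4-methylphenyl: methyl in place of hydrogen on an aromatic carbon. Going by the values given here, no measured pair isolates this change, so its size cannot be read from data.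

Among the compounds with values here, with only one number as an anchor, the expectation in this assay is a small step with no firm direction, probably not beyond the usual scatter of repeated measurements. The expected change is a 1.1-fold higher number from compound 2 to compound 3 (0.06 log units; within the scatter). Within the data shown here, the range is kept wide, since it rests on the single value of compound 2 at 175000 nM. For compound 3 the estimate is 200000 nM, with an expected range of 80000 nM to 500000 nM.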

Compound 3, concentration for 50% growth inhibition: > 629000 nM
Compound 3 gave a limit, no number; the forecaster's own chance of this, stated with the estimate: 15%; middle value at least 3.1-fold (0.49 log units) from the limit.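

Methyl in place of hydrogen on an aromatic carbon, para to a large group, now has a direction in this assay: the change from phenyl to 4-methylphenyl gives an at least 3.5-fold higher number from compound 2 to compound 3 (0.55 log units; beyond the scatter), the first step in the series that can be read and the first beyond the scatter. For the compounds shown here, the full size of this step stays unknown, since the value at its far end is a limit and not a number: the limit of > 629000 nM in this assay, at which 1 of the 3 values shown sits. The other new step, the one that links compound 1 and compound 3, cannot be read, since both of its ends are limits.

Still open, from the compounds shown here alone, is whether this position responds to the size of the group or to methyl alone, which a methoxy group, a fluoro group or an ethyl group on the same aromatic carbon would help to separate. Going by these compounds alone, also open is how large the methyl step is when measured against an actual number, since compound 2 remains the only compound here with one, at 175000 nM.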